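The source may report more compounds than this note shows. Statements on the series, on what has been measured and on what is new or still open speak of the compounds shown alone.

Of the compounds shown here, three built on one shared core have been measured in an ADME assay on Vero cells (Chlorocebus sabaeus) for cytotoxicity; a lower number here means that less compound is tolerated, a higher number that more compound is tolerated. Compound 1 `COc1ccc(-c2nc3c(C(=O)Nc4ccccc4F)cccc3[nH]2)cc1OC` gives 24.5 uM, compound 2 `COc1ccc(-c2nc3c(C(=O)NCCCO)cccc3[nH]2)cc1OC` gives 46 uM, and compound 3 `COc1ccc(-c2nc3c(C(=O)Nc4cnccn4)cccc3[nH]2)cc1OC` gives 98.8 uM, the highest number of the three. The steps leading to it, a 4.0-fold higher number from compound 1 to compound 3 (0.61 log units; beyond the scatter) and a 2.1-fold higher number from compound 2 to compound 3 (0.33 log units; beyond the scatter), show the pyrazin-2-yl amide as the best tolerated of the three amide groups. Compound 4 `COc1ccc(-c2nc3c(C(=O)Nc4ncccc4O)cccc3[nH]2)cc1OC` differs from compound 3 by 3-hydroxypyridin-2-yl in place of pyrazin-2-yl on an amide-type nitrogen. Within the data shown here, no measured step exchanges one six-membered aromatic amide substituent for another, so the earlier steps bear only loosely; the one aromatic-to-aromatic exchange, from compound 1 to compound 3, was modest. The step of a 1.4-fold lower number from compound 3 to compound 4 (0.15 log units; within the scatter) is therefore expected to be small, leaning lower. Compound 4 is estimated at 70 uM, in a range from 25 uM to 160 uM.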

Compound 4, half-maximal toxic concentration: 164 uM
Compound 4: the middle estimate sits 2.3-fold (0.37 log units) below what was measured; measured number above the stated range.
By their numbers in this assay, from the lowest: compounds 1 and 2 (each within the scatter of the next); then compounds 3 and 4 (each within the scatter of the next).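

On the amide-type nitrogen, swapping pyrazin-2-yl for 3-hydroxypyridin-2-yl gives a 1.7-fold higher number from compound 3 to compound 4 (0.22 log units; within the scatter) and stays within the scatter, so this assay does not separate these two aromatic rings. Compound 4 also clears both remaining amides, with a 3.6-fold higher number from compound 2 to compound 4 (0.55 log units; beyond the scatter) and a 6.7-fold higher number from compound 1 to compound 4 (0.83 log units; beyond the scatter) both beyond the scatter, so the tolerance seen with compound 3 holds for a second ring that carries a ring nitrogen. Still open, on these data alone, is whether the hydroxyl matters, which plain pyridin-2-yl would test, or whether a ring bearing an amine or a carboxylic acid would fare the same. Nothing available explains these differences.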